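This account rests on a few compounds, and the source may have more. Where it says the series, first, only, none or still open, it means among the compounds named here.

Measured so far in a functional assay on MGC-803 cells (Homo sapiens) for antiproliferative activity, read by CCK-8 assay, with a stated time of 72 h, tested at 2 uM; a higher number here means a stronger effect of the compound at the concentration tested, a lower number a weaker effect:
compound 1 `Nc1ccccc1NC(=O)c1ccc(CSC(=S)N2CCc3ccccc32)cc1` gives 44%;
compound 2 `COc1ccc(N2CCN(C(=S)SCc3ccc(C(=O)Nc4ccccc4N)cc3)CC2)cc1` gives 25.3%;
compound 3 `Nc1ccccc1NC(=O)c1ccc(CSC(=S)N2CCCc3ccccc32)cc1` gives 38.5%.

Compound 2 stands lowest of the three in this assay; its gaps to compound 3 and to compound 1 are both beyond the scatter. Within the data shown here, the single measured step, a number 5.5 percentage points lower from compound 1 to compound 3 (within the scatter), concerns the ring on the thiocarbonyl carbon and lies within the scatter; it says nothing about the amine nitrogen in the six-membered ring. Compound 4 `Nc1ccccc1NC(=O)c1ccc(CSC(=S)N2CCN(Cc3ccccc3)CC2)cc1` differs from compound 2 by benzyl in place of 4-methoxyphenyl on an amine nitrogen in a ring. Among the measured compounds shown here, no measured step bears on this change, so its size and direction remain open. The starting point is low because compound 2 gives 25.3%, leaving room upward. A moderate rise is therefore expected, a number 7.7 percentage points higher from compound 2 to compound 4 (within the scatter). Compound 4 is estimated at 33%, with an expected range from 15% to 50%.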

Compound 4, a percentage reported as inhibition, at one concentration (the size of the read-out at that concentration, not a potency): 18.1%
For compound 4 the middle estimate is 14.9 percentage points above the measured one, within the range that was stated.
By their numbers in this assay, from the lowest: compounds 4 and 2 (each within the scatter of the next); then compounds 3 and 1 (each within the scatter of the next).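

In this assay the step on the amine nitrogen in the ring, a number 7.2 percentage points lower from compound 2 to compound 4 (within the scatter) for benzyl in place of 4-methoxyphenyl, stays within the scatter. At this position, then, the two aromatic groups are not told apart, and losing the one hydrogen-bond acceptor of 4-methoxyphenyl brings no change that can be read. No available evidence accounts for this result. Still open, as far as these compounds go, is whether a group without an aromatic ring on this nitrogen, such as methyl or a hydroxyethyl chain, would give a step beyond the scatter.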